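The source may hold more compounds than are shown below. What is called first, only, known or untested is meant among the compounds shown, and "the series" means these compounds.

Working notes on the series.

Three compounds share one core, varied only at the amide-type nitrogen on the cyclopropane-dicarboxamide arm. Compound 1 `CN(C)C(=O)c1cc2cnc(Nc3ccc(NC(=O)C4(C(=O)Nc5ccccc5)CC4)cc3)nc2n1C1CCCC1` gives 75% in a functional assay on A549 cells (Homo sapiens) for inhibition, read by CCK-8 assay, with a stated time of 72 h, tested at 1 uM; on this read-out higher numbers stand for more inhibition of growth at the one concentration tested and lower numbers for less inhibition of growth. Compound 2 `CN(C)C(=O)c1cc2cnc(Nc3ccc(NC(=O)C4(C(=O)Nc5ccccc5F)CC4)cc3)nc2n1C1CCCC1` gives 79.1% in this assay, and the step of a number 4.1 percentage points higher from compound 1 to compound 2 (within the scatter) leaves the two indistinguishable. Compound 3 `COC(=O)c1cccc(NC(=O)C2(C(=O)Nc3ccc(Nc4ncc5cc(C(=O)N(C)C)n(C6CCCC6)c5n4)cc3)CC2)c1` gives 10.5% in this assay and stands lowest of the three, with the nearest number, that of compound 1, and the furthest, that of compound 2, both well beyond the scatter above it.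

Compound 4 `CN(C)C(=O)c1cc2cnc(Nc3ccc(NC(=O)C4(C(=O)Nc5ccc(F)cc5)CC4)cc3)nc2n1C1CCCC1` is not yet measured. Its difference from compound 3: 4-fluorophenyl in place of 3-(methoxycarbonyl)phenyl on an amide-type nitrogen. The relevant measured steps are a number 64.5 percentage points lower from compound 1 to compound 3 (beyond the scatter) and a number 68.6 percentage points lower from compound 2 to compound 3 (beyond the scatter), both large; moving away from the methoxycarbonyl-bearing ring to a fluorophenyl therefore reverses those drops, and the small step of a number 4.1 percentage points higher from compound 1 to compound 2 (within the scatter) suggests a fluorine on the phenyl alters little. A large rise in this assay is expected, a number 65.5 percentage points higher from compound 3 to compound 4 (beyond the scatter). Compound 4 is estimated at 76%, within 60% to 88%.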

Compound 4, percent growth inhibition at one concentration: 86.6%
For compound 4 the middle estimate is 10.6 percentage points below the measured one; the range from low to high includes it.
By their numbers in this assay, from the lowest: compound 3; then compounds 1, 2 and 4 (each within the scatter of the next, the first and the last beyond it).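

In this assay, the change to 4-fluorophenyl on the amide-type nitrogen gives a number 76.1 percentage points higher from compound 3 to compound 4 (beyond the scatter), so a high number is reached again with a substituted phenyl, and the low number of compound 3 is not a feature of substitution on this ring as such. Moving the fluoro from the 2-fluorophenyl to the 4-fluorophenyl gives a number 7.5 percentage points higher from compound 2 to compound 4 (within the scatter), so these two fluorophenyl groups are not told apart, whereas adding fluoro to the plain phenyl now gives a number 11.6 percentage points higher from compound 1 to compound 4 (beyond the scatter), the first fluoro step in the series to pass the scatter. Nothing available on these compounds bears on the reason for these steps.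

From the compounds shown here alone, whether the loss in compound 3 belongs to the methoxycarbonyl group itself or to its place on the ring remains open. Also open, going by these compounds, is whether a carboxylic acid, a primary amide or a chlorine on this phenyl ring would follow the methoxycarbonyl group or the fluoro.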